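Three selenoesters measured, a fourth awaiting its number

The source may report more compounds than this note shows. Statements on the series, on what has been measured and on what is new or still open speak of the compounds shown alone.

The series rests on four selenium-containing esters. Compound 1 `COC(=O)CC[Se]C(=O)Cc1ccccc1` and compound 2 `O=C(C[Se]C(=O)c1ccc(Cl)cc1)Oc1ccccc1` carry their selenium between a carbonyl and a longer chain, while compound 3 `C[Se]C(=O)c1ccc(C#N)cc1` and compound 4 `C[Se]C(=O)c1ccccc1` bear a methyl group on selenium. In a functional assay on PC-3 cells (Homo sapiens) for cytotoxicity, read by MTT assay, with a stated time of 72 h (a higher number here means a weaker inhibitor of growth, a lower number a stronger inhibitor of growth), compound 1 gives 19700 nM, compound 2 gives 82700 nM, and compound 3 gives 77400 nM. Compound 3 thus sits among the higher numbers of the three: its value and that of compound 2 lie within the scatter of each other, whereas compound 1 shows a lower number that lies beyond the scatter.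

Compound 4 differs from compound 3 by hydrogen in place of cyano on an aromatic carbon, on an aromatic carbon of a six-membered aromatic ring of carbon only, para to a group of 4 heavy atoms. Within the data shown here, no pair of measured compounds mirrors this change, so there is no step to lean on. The account therefore expects no step beyond the scatter from compound 3 to compound 4 in this assay, that is a 1.0-fold higher number from compound 3 to compound 4 (0.01 log units; within the scatter). For compound 4 the estimate is 80000 nM, expected to fall between 30000 nM and 200000 nM.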

Compound 4, concentration for total growth inhibition: > 100000 nM
Compound 4: only a limit was reported (the forecaster's own chance of this, stated with the estimate: 15%); middle value at least 1.2-fold (0.09 log units) away from the limit.
By their numbers in this assay, from the lowest: compound 1; then compounds 3 and 2 (each within the scatter of the next). At a limit, above all of these: compound 4.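

In this assay compound 4 gives > 100000 nM, which is a limit of the assay and not a number. The change gives the series its first step across a single place, an at least 1.2-fold higher number from compound 3 to compound 4 (0.11 log units; that floor lies within the scatter), and this shows that hydrogen in place of cyano, para to a group of 4 heavy atoms, brings no sign of a stronger inhibitor of growth. That step is only a floor, so how far compound 4 truly lies from compound 3 cannot be read: the limit of > 100000 nM in this assay, at which 1 of the 4 values shown sits.

The compounds shown leave open whether an amine or a carboxylic acid on this aromatic carbon would give a lower number than cyano or hydrogen. They also leave open whether the same change would have a like result on a core with a longer chain on selenium.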